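Halogenated aryl groups on the ring nitrogen of compound 1

The compounds below may be only part of what the source reports. "The series", "measured", "known", "first", "only" and "open" are said of these compounds alone.

Measured compounds:
compound 1, `CCCn1c(=O)[nH]c2nc(-c3ccc(S(=O)(=O)N4CCN(Cc5cccc(Br)c5)CC4)cc3)[nH]c2c1=O` — 0.148 nM
compound 2, `CCCn1c(=O)[nH]c2nc(-c3ccc(S(=O)(=O)N4CCN(c5cccc(Br)c5)CC4)cc3)[nH]c2c1=O` — 0.234 nM
compound 3, `CCCn1c(=O)[nH]c2nc(-c3ccc(S(=O)(=O)N4CCN(c5ccccc5)CC4)cc3)[nH]c2c1=O` — 0.643 nM

All three were tested in an assay on CHO cells for displacement of a labelled ligand from adenosine receptor A2b (Homo sapiens), read by scintillation counting, with a stated time of 75 min, in the presence of a further agent that is not named here; on this read-out lower numbers stand for stronger inhibition and higher numbers for weaker inhibition. Compound 1 gives the lowest number of the three; compound 2 is nearest, with a 1.6-fold higher number from compound 1 to compound 2 (0.20 log units; within the scatter), and compound 3 is furthest, with a 4.3-fold higher number from compound 1 to compound 3 (0.64 log units; beyond the scatter). Compound 4, `CCCn1c(=O)[nH]c2nc(-c3ccc(S(=O)(=O)N4CCN(c5ccccc5Cl)CC4)cc3)[nH]c2c1=O`, has not yet been measured. Its change from compound 1 is 2-chlorophenyl in place of 3-bromobenzyl on an amine nitrogen in a ring.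

Within the data shown here, two measured steps bear on this change. Replacing the 3-bromobenzyl with a 3-bromophenyl gave a 1.6-fold higher number from compound 1 to compound 2 (0.20 log units; within the scatter), so moving the aryl ring directly onto the nitrogen costs little. Removing the bromo from that phenyl gave a 2.7-fold higher number from compound 2 to compound 3 (0.44 log units; beyond the scatter), so a halogen on the ring helps. Compound 4 keeps a halogen, chlorine instead of bromine, in a differently named group, 2-chlorophenyl, for which there is no direct comparison. A modest weakening relative to compound 1 is expected, roughly a 2.7-fold higher number from compound 1 to compound 4 (0.43 log units; beyond the scatter), landing between compound 2 and compound 3. Compound 4 is therefore estimated at 0.4 nM, within 0.15 nM to 1.2 nM.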

Compound 4, inhibition constant: 0.403 nM
The estimate for compound 4 lay 1.0-fold (0.00 log units) below the measured number; the measured number falls inside the stated range.
By their numbers in this assay, from the lowest: compounds 1, 2, 4 and 3 (each within the scatter of the next, the first and the last beyond it).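

Compound 4 brings the first chlorine into the series, and exchanging the 3-bromobenzyl for 2-chlorophenyl gives a 2.7-fold higher number from compound 1 to compound 4 (0.44 log units; beyond the scatter). Adding the chloro to the plain phenyl gives a 1.6-fold lower number from compound 3 to compound 4 (0.20 log units; within the scatter), and exchanging 3-bromophenyl for 2-chlorophenyl gives a 1.7-fold higher number from compound 2 to compound 4 (0.24 log units; within the scatter), so compound 4 cannot be separated from either compound 2 or compound 3, even though those two lie apart by a 2.7-fold higher number from compound 2 to compound 3 (0.44 log units; beyond the scatter). Nothing measured here offers an explanation for these numbers.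

Compounds 2 and 4 differ in both the halogen and its place on the ring, so the two effects cannot be told apart; 3-chlorophenyl or 2-bromophenyl would separate them. Going by these compounds, whether a methoxy group or an amine on that phenyl ring could stand in for the halogen also remains open.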